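Notes on replacing piperidin-1-yl in compound 2

The source may hold more compounds than are shown below. What is called first, only, known or untested is meant among the compounds shown, and "the series" means these compounds.

Measured values in a functional assay on the whole organism with Rattus norvegicus as the target; on this read-out higher numbers stand for an effect only at larger amounts of compound and lower numbers for an effect already at smaller amounts:
- compound 1 `CSCCn1c(=N)sc2cc(OC(F)(F)F)ccc21` gives 1 mg/kg
- compound 2 `N=c1sc2cc(OC(F)(F)F)ccc2n1CCN1CCCCC1` gives 2 mg/kg

Only these two numbers are available so far, and compound 2 (2 mg/kg) lies within the scatter of compound 1 (1 mg/kg).

The next compound is compound 3 `CC[S+]([O-])CCn1c(=N)sc2cc(OC(F)(F)F)ccc21`, and its change from compound 2 is a group of 4 heavy atoms (2 carbon, 1 oxygen, 1 sulfur; no ring) in place of a group of 6 heavy atoms (5 carbon, 1 nitrogen; one six-membered non-aromatic ring with 1 hetero atom), on a saturated chain carbon, two bonds along the chain from an aromatic nitrogen. The entering group has not been measured on this core, so direct evidence for it is lacking.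

Within the data shown here, one measured step bears on the change, as it sits at the same place on a saturated chain carbon. This is a 2.0-fold higher number from compound 1 to compound 2 (0.30 log units; within the scatter), where piperidin-1-yl replaces methylsulfanyl. That single step sets a small precedent, and it gives no direction for compound 3. No step beyond the scatter is therefore expected in this assay. The estimated step is a 1.3-fold lower number from compound 2 to compound 3 (0.12 log units; within the scatter) (no direction is firmly expected). For compound 3 the expected value is 1.5 mg/kg (estimated range 0.5 mg/kg to 5 mg/kg).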

Compound 3, dose for half-maximal effect: 1.2 mg/kg
The estimate for compound 3 lay 1.3-fold (0.10 log units) above the measured number; low and high end bracket the measured number.
By their numbers in this assay, from the lowest: compounds 1, 3 and 2 (each within the scatter of the next).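

In this assay the place on a saturated chain carbon, two bonds along the chain from an aromatic nitrogen, now carries a third group, and swapping piperidin-1-yl for the group of 4 heavy atoms (2 carbon, 1 oxygen, 1 sulfur; no ring) gives a 1.7-fold lower number from compound 2 to compound 3 (0.22 log units; within the scatter). The same group in place of methylsulfanyl gives a 1.2-fold higher number from compound 1 to compound 3 (0.08 log units; within the scatter), so a group holding both sulfur and oxygen stays within the scatter of the two groups already seen, one with a six-membered non-aromatic ring and one without a ring. With all three steps within the scatter, neither the presence of a ring nor the size of the group separates these compounds in this assay, and nothing measured here accounts for this flat picture.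

The compounds shown leave open whether any group at this place produces a step beyond the scatter, for instance a carboxylic acid, a primary amine or a longer alkyl chain. They also leave open whether the sulfur of the entering group matters at all, a question that a simple ethoxy group at the same place would address.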